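The source may report more compounds than this note shows. Statements on the series, on what has been measured and on what is new or still open speak of the compounds shown alone.

In a physicochemical assay for solubility, in phosphate buffer, measured as kinetic solubility (a higher number here means a more soluble compound, a lower number a less soluble compound), compound 1 `CC(C)C(CC1C(=O)NC(=O)N1C)c1ccc(-c2ccc3cccc(F)c3c2)[nH]c1=O` gives 33600 nM as its result. Compound 2 `CC(C)[C@H](C[C@H]1OC(=O)NC1=O)c1ccc(-c2ccc3cccc(F)c3c2)[nH]c1=O` gives 35400 nM in the same test, so the two compounds lie within the usual scatter of each other and cannot be told apart on these numbers. Compound 3 `CC(C)C(CC1NC(=O)NC1=O)c1ccc(-c2ccc3cccc(F)c3c2)[nH]c1=O` has not yet been measured. It differs from compound 1 in one place, counted as hydrogen in place of methyl on an amide-type nitrogen in a ring in full: hydrogen in place of methyl on an amide-type nitrogen in a ring, which turns the 3-methyl-2,5-dioxoimidazolidin-4-yl group into 2,5-dioxoimidazolidin-4-yl. Among the measured compounds shown here, no measured pair here differs in a single place, so the data give no direct guide to this swap. For the measured compounds named here, the only support is that compound 1 at 33600 nM and compound 2 at 35400 nM read alike with different groups on the shared core. No step beyond the scatter is expected in this assay in either direction. The estimated step is a 1.1-fold lower number from compound 1 to compound 3 (0.05 log units; within the scatter) and is expected to stay small. For compound 3 the estimated value is 30000 nM with an expected range from 13000 nM to 70000 nM for repeat measurements.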

Compound 3, solubility: 12300 nM
For compound 3 the middle estimate is 2.4-fold (0.39 log units) above the measured one, and the stated range ends above it.
By their numbers in this assay, from the lowest: compound 3; then compounds 1 and 2 (each within the scatter of the next).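

In this assay, taking the methyl off the amide-type nitrogen in the ring turns the 3-methyl-2,5-dioxoimidazolidin-4-yl group into 2,5-dioxoimidazolidin-4-yl and gives a 2.7-fold lower number from compound 1 to compound 3 (0.44 log units; beyond the scatter), a modest step but one that stands clear of the usual noise between repeats. Among the compounds shown here, this is the first pair that differs in a single place, so it shows something the earlier values could not: at this ring nitrogen, the loss of one methyl, a single carbon replaced by a hydrogen atom, is enough to move the reading. No measurement at hand accounts for this drop, so the result stands as an observation without an explanation.

The compounds shown carry only methyl or hydrogen on this nitrogen, so it remains open whether an ethyl group, a longer chain or a chain ending in an alcohol would keep the number near that of compound 1 or shift it further. One pair also cannot tell whether the same swap would give a step of similar size elsewhere in the series.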